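The compounds below may be only part of what the source reports. "The series", "measured", "known", "first", "only" and "open" are said of these compounds alone.

Among the measured compounds shown here, compound 2 `CCN(CC)C(=O)CC1CCc2cc(OC)c(OC)cc21` stands highest of the two numbers so far in a functional assay on the whole organism (strain Wistar) for inhibition, with Rattus norvegicus as the target, read by paw edema, with stated times of 60 min and 2 h, at a dose of 100 mg/kg by the oral route; a higher number here means more inhibition at the dose given (going by the name of the read-out), a lower number less inhibition: compound 2 gives 40%, whereas compound 1 `COc1cc2c(cc1OC)C(CC(=O)O)CC2` gives 24%. For the measured compounds named here, that gap is the single measured step, a number 16 percentage points higher from compound 1 to compound 2 (beyond the scatter), which came from putting diethylamino in place of hydroxy on a carbonyl carbon. Compound 3 `CCCNC(=O)CC1CCc2cc(OC)c(OC)cc21` differs from compound 2 by propylamino in place of diethylamino on a carbonyl carbon. Going by the values given here, no measured step replaces one amino group with another, so there is no direct guide for this change. The step of a number 4 percentage points lower from compound 2 to compound 3 (within the scatter) is expected to stay within the usual scatter. Compound 3 is therefore estimated at 36%, between 20% and 50%.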

Compound 3, a percentage reported as inhibition, in the whole organism at one dose (the size of the read-out at that dose, not a potency): 28%
For compound 3 the middle estimate is 8 percentage points above the measured one; the measured number falls inside the stated range.
By their numbers in this assay, from the lowest: compounds 1 and 3 (each within the scatter of the next); then compound 2.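

In this assay, the choice of amino group on the carbonyl carbon matters (  a number 12 percentage points lower from compound 2 to compound 3 (beyond the scatter)): propylamino in place of diethylamino is not a neutral exchange, and it brings in a hydrogen-bond donor. Turning the acid into an amide does not by itself secure the improvement seen with compound 2, as compound 3 cannot be told apart from compound 1 (a number 4 percentage points higher from compound 1 to compound 3 (within the scatter)). Nothing available explains the difference between these two amino groups. On these data alone, it remains open whether dipropylamino or ethylamino would follow compound 2 or compound 3, and how a cyclic amine such as piperidine would fare.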